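The source may hold more compounds than are shown below. What is called first, only, known or untested is meant among the compounds shown, and "the series" means these compounds.

Compound 1 `CC(=O)NN=C1C(Cl)=C(Cl)C(Cl)=C1Cl` and compound 2 `CC(C)(C)OC(=O)NN=C1C(Cl)=C(Cl)C(Cl)=C1Cl` share the same core, a tetrachlorinated ring carrying a hydrazone linker; they differ in what sits on the carbonyl carbon attached to the amide-type nitrogen. In a functional assay on MM1.S cells (Homo sapiens) for cytotoxicity, read by MTT assay, with a stated time of 48 h (on this read-out lower numbers stand for stronger inhibition and higher numbers for weaker inhibition), compound 1 gives "not determined" (no result reported), so no number is available for it. In this assay, going by the values given here, compound 2 gives 600 nM, and this is the only number available, so it stands alone as the reference point.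

Compound 3 `CC(C)(C)C(=O)NN=C1C(Cl)=C(Cl)C(Cl)=C1Cl` is the next member. The change from compound 2 to compound 3 is tert-butyl in place of tert-butoxy on a carbonyl carbon. The oxygen that linked the carbonyl to the branched chain is gone, and the chain now bonds directly to the carbonyl carbon.

Among the compounds with values here, no measured pair in the set shows what such a change does, so the size of the step can only be guessed. Given that compound 2 shows 600 nM, the expected step from compound 2 to compound 3 is a 1.3-fold higher number from compound 2 to compound 3 (0.12 log units; within the scatter), a small loss that may well sit within the usual scatter. Compound 3 is therefore estimated at 800 nM in this assay, with a plausible range from 300 nM to 2500 nM.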

Compound 3, half-maximal inhibitory concentration: 2000 nM
For compound 3 the middle estimate is 2.5-fold (0.40 log units) below the measured one; measured number inside the range.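

In this assay, going by these compounds alone, the exchange of tert-butoxy for tert-butyl on a carbonyl carbon gives a 3.3-fold higher number from compound 2 to compound 3 (0.52 log units; beyond the scatter), the first measured step, and it shows that the number responds to the group held at this position. The branched group keeps its carbons in both compounds, and what leaves is the oxygen, along with the hydrogen-bond acceptor counted for tert-butoxy, so this modest step accompanies a narrow change, although one pair cannot separate the two features. No measurement given here bears on the reason for the step.

In this assay, from the compounds shown here alone, compound 1 gives "not determined" (no result reported), so its steps to the other two compounds cannot be read, and the effect of the small methyl group it carries on the carbonyl remains unknown. Going by these compounds, it also remains open whether an amine, a phenyl ring or a longer chain on that carbonyl carbon would give a number closer to that of compound 2 or to that of compound 3, and whether the step seen here would hold on a different core.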